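The source may report more compounds than this note shows. Statements on the series, on what has been measured and on what is new or still open speak of the compounds shown alone.

Compound 1 `O=C(O)Cc1sc(CS(=O)(=O)c2ccc(Cl)cc2)nc1-c1ccc(Cl)cc1`: 1500 nM
Compound 2 `O=C(O)Cc1sc(COc2ccc(Cl)cc2)nc1-c1ccc(Cl)cc1`: 32 nM
Compound 3 `O=C(O)Cc1sc(C(c2ccc(F)cc2)c2ccc(F)cc2)nc1-c1cc(F)cc(F)c1`: 35 nM

These three compounds share a core and were all tested in an in vitro assay on HEK385-7 cells for displacement of a labelled ligand from prostaglandin D2 receptor 2 (Homo sapiens); a higher number here means a weaker inhibitor, a lower number a stronger inhibitor. Among the three numbers, compound 3 has the second highest. Its nearest neighbour is compound 2, and the gap between them lies within the scatter, so the two cannot be told apart. Compound 1 stands far away with a much higher number, a gap well beyond the scatter.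

Compound 4 `CN(C)c1cc(-c2nc(C(c3ccc(F)cc3)c3ccc(F)cc3)sc2CC(=O)O)ccn1` has not yet been measured. It differs from compound 3 in a single place: 2-(dimethylamino)pyridin-4-yl in place of 3,5-difluorophenyl on an aromatic carbon. The new group sits on an aromatic carbon of a five-membered aromatic ring with 1 nitrogen and 1 sulfur, two ring bonds from the ring atom that bears a large group.

Among the compounds with values here, no measured pair shows a change of this kind, so the direction has to be guessed. The expected step from compound 3 to compound 4 is small, a 1.4-fold higher number from compound 3 to compound 4 (0.15 log units; within the scatter), and may well stay within the scatter. Compound 4 is therefore estimated at 50 nM, with a range from 10 nM to 250 nM.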

Compound 4, half-maximal inhibitory concentration: 380 nM
Compound 4: middle estimate off by 7.6-fold (0.88 log units), on the low side; the measured number lies above the stated range.
By their numbers in this assay, from the lowest: compounds 2 and 3 (each within the scatter of the next); then compound 4; then compound 1.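

In this assay, putting 2-(dimethylamino)pyridin-4-yl in place of 3,5-difluorophenyl on this aromatic carbon gives an 11-fold higher number from compound 3 to compound 4 (1.04 log units; beyond the scatter), a large step well beyond the scatter. This is the first single-place change shown at this position, and it shows that the group held here can strongly affect the number, with this replacement making the inhibitor weaker. No measurement is available to explain why this swap has such a large effect.

The change alters several things at once, so the compounds shown leave open whether the step follows from the hetero atom in the new ring, the dimethylamino group or the loss of the fluorines. A plain pyridin-4-yl or a dimethylaminophenyl group at this place would help to separate these contributions.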